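Methoxy on the 4-fluorobenzyl group of compound 1

A few compounds are considered here, and "the series" means these few. Any claim that something is new, unique, unknown or untested is made for them only; others in the source may bear on it.

In an ADME assay on 2209-23 cells (Homo sapiens) for cytotoxicity, read by WST assay and thymidine incorporation (on this read-out lower numbers stand for higher toxicity in this test and higher numbers for lower toxicity in this test), compound 1 `CC(C)(C)[C@H]1C(O)=C(C2=CS(=O)(=O)c3cc(NS(C)(=O)=O)ccc3N2)C(=O)N1Cc1ccc(F)cc1` gives > 50000 nM as a limit of the assay, not a number. Compound 2 `CC(C)(C)[C@H]1C(O)=C(C2=C(Cl)S(=O)(=O)c3cc(NS(C)(=O)=O)ccc3N2)C(=O)N1Cc1ccc(F)cc1` gives > 50000 nM as a limit too. Compound 3 `CC(C)(C)[C@H]1C(O)=C(C2=CS(=O)(=O)c3cc([N+](=O)[O-])ccc3N2)C(=O)N1Cc1ccc(F)cc1` gives > 50000 nM as a limit too. The data so far therefore show the limit of > 50000 nM in this assay, at which 3 of the 3 values shown sit, and no exact number.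

Compound 4 `COc1cc(CN2C(=O)C(C3=CS(=O)(=O)c4cc(NS(C)(=O)=O)ccc4N3)=C(O)[C@@H]2C(C)(C)C)ccc1F` differs from compound 1 in one place, where 4-fluorobenzyl becomes 4-fluoro-3-methoxybenzyl, with methoxy in place of hydrogen on an aromatic carbon. Two measured changes made elsewhere in the molecule bear on this only loosely. Chloro in place of hydrogen gives a step that the two limits leave unreadable from compound 1 to compound 2 and nitro in place of methanesulfonamido gives a step that the two limits leave unreadable from compound 1 to compound 3 as the second case. Neither offers a size to carry over.

The estimated step is a number no higher from compound 1 to compound 4 (the limit leaves the size open) and no shift beyond the usual scatter is expected in this assay for this change. That expectation rests on compound 1 and its limit > 50000 nM alone. For compound 4 the estimate is 50000 nM with an expected range of 25000 nM to 100000 nM and a report at the limit is likely.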

Compound 4, half-maximal cytotoxic concentration: > 50000 nM
Compound 4 was reported as a limit; the forecaster's own chance of this, stated with the estimate: 85%; the middle value lies on the limit itself.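

No step can be read from compound 1 to compound 4, because both values are limits of the assay and not numbers: the limit of > 50000 nM in this assay, at which 4 of the 4 values shown sit.

The compounds shown leave open where the true values lie in this assay and so whether methoxy on the 4-fluorobenzyl group shifts the read-out at all.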